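The source may report more compounds than this note shows. Statements on the series, on what has been measured and on what is new or still open speak of the compounds shown alone.

Measured so far:
compound 1 `C=C1C(=O)[C@]23C[C@@]1(O)CC[C@H]2c1ccc(OS(=O)(=O)c2ccc(C)cc2)c(C)c1[C@@H]3Cn1cc(-c2ccccn2)nn1` — 2830 nM in a functional assay on SMMC-7721 cells (Homo sapiens) for cytotoxicity, read by MTT assay, with a stated time of 4 days; a lower number here means a stronger inhibitor, a higher number a weaker inhibitor
compound 2 `C=C1C(=O)[C@]23C[C@@]1(O)CC[C@H]2c1ccc(O)c(C)c1[C@@H]3Cn1cc(-c2ccc(F)cc2)nn1` — 850 nM in this assay

Of the two numbers, compound 2 holds the lower one; the nearest is compound 1, whose value is beyond the scatter from it. For the measured compounds named here, compound 1 and compound 2 differ at two places at once, so no single step between measured compounds can be read off.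

Compound 3 `C=C1C(=O)[C@]23C[C@@]1(O)CC[C@H]2c1ccc(OS(=O)(=O)c2ccc(C)cc2)c(C)c1[C@@H]3Cn1cc(-c2ccc(F)cc2)nn1` keeps the whole of compound 2 except for one change: (4-methylphenyl)sulfonyl in place of hydrogen on an oxygen on an aromatic ring. Whether this change alone moves the number cannot be taken from compound 1, since the triazole substituent differs there as well. A moderate step toward a higher number in this assay is expected, but with wide uncertainty. The step from compound 2 to compound 3 is estimated as a 1.9-fold higher number from compound 2 to compound 3 (0.27 log units; within the scatter). Compound 3 is expected to give about 1600 nM, within a range from 500 nM to 5000 nM.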

Compound 3, half-maximal inhibitory concentration: 4280 nM
Estimate against measurement, compound 3: 2.7-fold (0.43 log units) below; low and high end bracket the measured number.
By their numbers in this assay, from the lowest: compound 2; then compounds 1 and 3 (each within the scatter of the next).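

In this assay the exchange at the oxygen on an aromatic ring can now be read alone: (4-methylphenyl)sulfonyl in place of hydrogen gives a 5.0-fold higher number from compound 2 to compound 3 (0.70 log units; beyond the scatter) and so counts as a real step against the hydroxy form when 4-fluorophenyl is held constant. With the (4-methylphenyl)sulfonyl group held constant, 4-fluorophenyl in place of pyridin-2-yl on an aromatic carbon gives a 1.5-fold higher number from compound 1 to compound 3 (0.18 log units; within the scatter) and so shows no separable effect of that exchange in this pair. No measurement at hand accounts for the step at the oxygen.

As far as these compounds go, whether the step at the oxygen also holds with pyridin-2-yl on that aromatic carbon stays open. Also open, from the compounds shown here alone, is how a smaller group on the oxygen, such as methyl or acetyl, would compare with hydrogen and (4-methylphenyl)sulfonyl.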